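The source may report more compounds than this note shows. Statements on the series, on what has been measured and on what is new or still open speak of the compounds shown alone.

In a functional assay on the whole organism for inhibition, with Mus musculus as the target (a lower number here means that less compound is needed, a higher number that more compound is needed for the effect), compound 1 (`CN1Cc2c(N)cccc2C(c2ccc(Cl)cc2)C1`) gives 1.6 mg/kg. Going by the values given here, compound 2 (`CCNCC(=O)Nc1cccc2c1CN(C)CC2c1ccc(Cl)cc1`) gives 24 mg/kg, the highest of the two numbers so far. Among the compounds with values here, the only measured step is a 15-fold higher number from compound 1 to compound 2 (1.18 log units; beyond the scatter), with ((ethylamino)methyl)carbonyl in place of hydrogen on a nitrogen on an aromatic ring.

Compound 3 (`CCCCNCC(=O)Nc1cccc2c1CN(C)CC2c1ccc(Cl)cc1`) differs from compound 2 by ethyl in place of hydrogen on a saturated chain carbon, two bonds along the chain from an amine nitrogen, which turns ethylamino into butylamino. The measured step bears on this only indirectly, since it concerns the whole side chain. Within the data shown here, no measured pair varies the group on the amine, so no shift beyond the scatter is expected in this assay, though the uncertainty is wide. The expected step is a 1.1-fold lower number from compound 2 to compound 3 (0.04 log units; within the scatter). For compound 3 the estimate is 22 mg/kg, with an expected range of 8 mg/kg to 60 mg/kg.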

Compound 3, dose for half-maximal effect: 13.5 mg/kg
Beside the measured number, compound 3's estimate is 1.6-fold (0.21 log units) above it; the range from low to high includes it.
By their numbers in this assay, from the lowest: compound 1; then compounds 3 and 2 (each within the scatter of the next).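

In this assay, going by these compounds alone, the change from ethylamino to butylamino is the first variation at the amine end of the side chain. It gives a 1.8-fold lower number from compound 2 to compound 3 (0.25 log units; within the scatter) and so shows no shift that can be separated from the scatter when ethyl enters on this saturated chain carbon. The butylamino side chain as a whole still leaves an 8.4-fold higher number from compound 1 to compound 3 (0.93 log units; beyond the scatter) as a gap beyond the scatter, so compound 1, with hydrogen on the aromatic nitrogen, keeps the lowest number of the three. No measured evidence bears on the reason for these numbers.

Going by these compounds, it remains open whether a longer chain such as hexylamino, a branched group such as isopropylamino, or a carboxylic acid at the chain end would move the number beyond the scatter. Also open, on these data alone, is whether any acylated side chain on this nitrogen can come within the scatter of compound 1.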